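The source may report more compounds than this note shows. Statements on the series, on what has been measured and on what is new or still open speak of the compounds shown alone.

Compound 1, `CCCCC1(O)C(=O)Nc2ccc(Nc3ccc(C)cc3)cc21`, gives 7500 nM in a functional assay on A549 cells (Homo sapiens) for antiproliferative activity, read by MTT assay, with a stated time of 48 h; on this read-out higher numbers stand for weaker inhibition and lower numbers for stronger inhibition. For the measured compounds named here, only one other compound has been measured beside it: compound 2, `Cc1ccc(Nc2ccc3c(c2)C(O)(CCC(C)C)C(=O)N3)cc1`, which gives 12500 nM in this assay. The gap between them is a 1.7-fold higher number from compound 1 to compound 2 (0.22 log units; within the scatter), a methyl in place of hydrogen on a saturated chain carbon bound to two saturated chain carbons, so the two numbers cannot be told apart, and compound 1 simply stands as one of two readings that agree with each other.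

Compound 3, `CCCCC1(O)C(=O)Nc2ccc(Nc3ccc(F)cc3)cc21`, has not yet been measured. It keeps the whole core of compound 1 and alters one group on the outer aromatic ring: fluoro in place of methyl on an aromatic carbon. Going by the values given here, no measured step touches that ring; the single step measured so far concerns the saturated chain and stayed within the scatter. Nothing measured therefore points to a change in either direction, and the expectation for compound 3 is a number close to that of compound 1, with no change at the digits printed from compound 1 to compound 3 (within the scatter) expected to remain within the scatter. For compound 3 the estimate in this assay is 7500 nM, with a range from 3000 nM to 19000 nM.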

Compound 3, half-maximal inhibitory concentration: 6500 nM
For compound 3 the middle estimate is 1.2-fold (0.06 log units) above the measured one; the range from low to high includes it.
By their numbers in this assay, from the lowest: compounds 3, 1 and 2 (each within the scatter of the next).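

The outer aromatic ring now has its first reading: in this assay, going from 4-methylphenyl to 4-fluorophenyl gives a 1.2-fold lower number from compound 1 to compound 3 (0.06 log units; within the scatter), so at this place, para to a large group, methyl and fluoro cannot be told apart. Among the three compounds shown, the change on the saturated chain and the change on this ring both leave the numbers in this assay within the scatter of one another, so neither place has yet shown any clear effect on the read-out. The data at hand offer no independent measurement that could explain why these two groups read alike.

With only methyl and fluoro shown at this ring position, it remains open whether an amine, a carboxylic acid or a methoxy group there would shift the number beyond the scatter, or whether this position simply tolerates many groups. All three compounds also share the same core, so the contribution of its hydroxyl group and the amide hydrogen to the activity cannot be judged from them.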